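The compounds below may be only part of what the source reports. "The series", "measured", "known", "first", "only" and "open" are said of these compounds alone.

Measured so far in a functional assay on HCC1806 cells (Homo sapiens) for inhibition, read by sulforhodamine B assay, tested at 10 uM; on this read-out higher numbers stand for more inhibition at the one concentration tested (going by the name of the read-out) and lower numbers for less inhibition:

compound 1 `CN1CCN(c2ccc(C3=NN(S(=O)(=O)c4ccc(C(F)(F)F)cc4)C(c4ccc(N(C)C)cc4)C3)cc2)CC1` — 27%
compound 2 `CN(C)c1ccc(C2CC(c3ccc(-n4cncn4)cc3)=NN2C(=O)c2cc(Cl)cc(Cl)c2)cc1` — 5.3%
compound 3 `Cc1ccc(S(=O)(=O)N2N=C(c3ccc(-n4cncn4)cc3)CC2c2ccc(N(C)C)cc2)cc1` — 27.7%

Compound 3 holds the highest number of the three, but its gap to compound 1 lies within the scatter, so the two cannot be ordered; only compound 2 stands clearly apart. Among the compounds with values here, the one single-point step in the set, a number 22.4 percentage points higher from compound 2 to compound 3 (beyond the scatter), exchanges the group on the ring nitrogen and is the largest difference seen.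

Compound 4 `CN(C)c1ccc(C2CC(c3ccc(-n4cncn4)cc3)=NN2S(=O)(=O)c2ccc(C(F)(F)F)cc2)cc1` keeps everything of compound 3 except one group on the sulfonyl-bearing ring: trifluoromethyl in place of methyl on an aromatic carbon. Within the data shown here, no measured step touches this exact change. The closest evidence is indirect: compound 1 carries the same trifluoromethyl-substituted sulfonyl aryl as compound 4, though on a different partner ring, and its value sits level with that of compound 3, which carries the methyl. That pair shows only that both substituents go with a number in the same band; it is not a controlled step, and it says nothing about the triazolyl-bearing series itself.

Given that, no movement beyond the scatter is expected in this assay, so a number 0.3 percentage points higher from compound 3 to compound 4 (within the scatter) is the expected step. For compound 4 the estimate is 28%, within 14% to 42%.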

Compound 4, a percentage reported as inhibition, at one concentration (the size of the read-out at that concentration, not a potency): 37%
Estimate against measurement, compound 4: 9 percentage points below, within the range that was stated.
By their numbers in this assay, from the lowest: compound 2; then compounds 1, 3 and 4 (each within the scatter of the next).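

Within this assay, the exchange of 4-methylphenyl for 4-(trifluoromethyl)phenyl on the sulfonyl gives a number 9.3 percentage points higher from compound 3 to compound 4 (within the scatter) and is the first reading of this position with all else held constant, so methyl and trifluoromethyl on this aromatic carbon, para to a large group, cannot be told apart here. The second one-place comparison concerns the other aryl group and gives a number 10 percentage points higher from compound 1 to compound 4 (within the scatter), so 1H-1,2,4-triazol-1-yl and 4-methylpiperazin-1-yl on an aromatic carbon cannot be told apart either, and the sulfonyl compounds 1, 3 and 4 remain one unresolved group in this assay at the one concentration tested. No measurement on these compounds bears on the reason for either step.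

The compounds shown leave open whether a group of a different kind at the same aromatic carbon, such as a nitrile, a methoxy group, a carboxylic acid or a primary amine, would move the number beyond the scatter. They also leave open whether the carbonyl-linked 3,5-dichlorophenyl group of compound 2 would behave differently with a 4-methylphenyl or 4-(trifluoromethyl)phenyl on the carbonyl.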